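The compounds below may be only part of what the source reports. "The series", "measured", "known", "first", "only" and "open" are said of these compounds alone.

In a physicochemical assay for acid dissociation, three related compounds have been measured. Compound 1 `CO[C@H]1C(=O)N2C(C(=O)C(C)(C)C)=C(CSc3nnc(C)s3)C(Sc3nnc(C)s3)S(=O)(=O)[C@H]12` gives 5.8, compound 2 `CO[C@H]1C(=O)N2C(C(=O)C(C)(C)C)=C(C)C(Sc3nnc(C)s3)S(=O)(=O)[C@H]12` gives 7.5 and compound 3 `CO[C@H]1C(=O)N2C(C(=O)c3ccccc3)=C(CSc3nnnn3C)C(Sc3nnnn3C)S(=O)(=O)[C@H]12` gives 3.5, so compound 2 stands highest of the three.

Compound 4 `CO[C@H]1C(=O)N2C(C(=O)C(C)(C)C)=C(C)C(Sc3nc(=O)c(=O)[nH]n3C)S(=O)(=O)[C@H]12` has not yet been measured. It differs from compound 2 by a single swap: a group of 9 heavy atoms (4 carbon, 3 nitrogen, 2 oxygen; one six-membered aromatic ring with 3 hetero atoms) in place of a group of 6 heavy atoms (3 carbon, 2 nitrogen, 1 sulfur; one five-membered aromatic ring with 3 hetero atoms), on a sulfur. The swap lies on a sulfur whose other neighbour is a saturated ring carbon.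

Going by the values given here, no measured step tests this swap directly. Among the compounds with values here, the only single-place step is a number 1.70 log units higher from compound 1 to compound 2 (beyond the scatter), with hydrogen in place of (5-methyl-1,3,4-thiadiazol-2-yl)sulfanyl on a saturated chain carbon. That is a different place, but the step shows that one change can move the number a long way in this series. Compound 3, at 3.5, shows that a much lower number is possible with another ring on the sulfur, although it also differs from compound 2 elsewhere.

Within the data shown here, the entering group holds a hydrogen-bond donor, which none of the measured compounds has, so a fall rather than a rise is expected, with wide uncertainty. The expected step is a number 3.20 log units lower from compound 2 to compound 4 (beyond the scatter), a large one. The estimate for compound 4 is 4.3, with an expected range from 3 to 6.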

Compound 4, acid dissociation constant: 8.9
Compound 4: the middle estimate sits 4.60 log units below what was measured; the measured number lies above the stated range.
By their numbers in this assay, from the lowest: compound 3; then compound 1; then compound 2; then compound 4.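

In this assay, going by these compounds alone, the swap on the sulfur whose other neighbour is a saturated ring carbon gives a number 1.40 log units higher from compound 2 to compound 4 (beyond the scatter) and so shows that this position, which no earlier single-place step had tested, can carry a large change. Within the data shown here, the direction is also new information: the entering six-membered aromatic ring holds a hydrogen-bond donor, which none of the earlier compounds has, and the number still goes up rather than down. Alongside a number 1.70 log units higher from compound 1 to compound 2 (beyond the scatter) at a different place, this gives two single-place steps in the series, both large and both upward, though two steps are too few to make a rule. Nothing measured here accounts for the direction or the size of this change.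

The compounds shown do not tell which part of the entering group matters, nor how a carboxylic acid or an amine on this sulfur would move the number. They also leave open whether the same swap would give a similar step in a compound that carries (5-methyl-1,3,4-thiadiazol-2-yl)sulfanyl on the saturated chain carbon, as compound 1 does.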